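Replacing the tetrazole phenyl by methyl on the tolyl thiazole

A few compounds are considered here, and "the series" means these few. Any claim that something is new, unique, unknown or untested is made for them only; others in the source may bear on it.

Compound 3 `Cc1ccc(-c2cs/c(=N/NC(=O)CSc3nnnn3-c3ccccc3)n2-c2ccccc2)cc1` is the point of departure. In an ADME assay on NIH3T3 cells (Mus musculus) for cytotoxicity, read by MTT assay, with a stated time of 24 h (a higher number here means a weaker inhibitor, a lower number a stronger inhibitor), compound 3 reaches only > 500 ug/mL, which is a limit of the assay rather than a number. Its nearest measured neighbour is compound 1 `O=C(CSc1nnnn1-c1ccccc1)N/N=c1/scc(-c2ccc(Br)cc2)n1-c1ccccc1`, which in this assay gives 433 ug/mL. The step of an at least 1.1-fold higher number from compound 1 to compound 3 (0.06 log units; that floor lies within the scatter) is therefore known only as a floor, because of the limit of > 500 ug/mL in this assay, at which 1 of the 3 values shown sits. Compound 2 `Cn1nnnc1SCC(=O)N/N=c1/scc(-c2ccc(F)cc2)n1-c1ccccc1` already carries the methyl tetrazole and in this assay gives 113 ug/mL; it differs from compound 1 in two places, so its value stands on its own beside those of compound 1 and compound 3.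

Compound 4 `Cc1ccc(-c2cs/c(=N/NC(=O)CSc3nnnn3C)n2-c2ccccc2)cc1` arises from compound 3 by methyl in place of phenyl on an aromatic nitrogen. Among the measured compounds shown here, no measured step isolates this change, so the expectation rests on the two values of compound 2 and compound 3 alone. Compound 4 is expected to give 300 ug/mL in this assay, with a range from 100 ug/mL to 500 ug/mL. That estimate corresponds to the step of an at least 1.6-fold lower number from compound 3 to compound 4 (0.22 log units; that floor lies within the scatter), a move toward the value seen for compound 2, though a result that again ends at the limit would not be surprising.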

Compound 4, half-maximal inhibitory concentration: 243 ug/mL
For compound 4 the middle estimate is 1.2-fold (0.09 log units) above the measured one, and the stated range covers the measured number.
By their numbers in this assay, from the lowest: compound 2; then compounds 4 and 1 (each within the scatter of the next). At a limit, above all of these: compound 3.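

In this assay, among the compounds shown here, the exchange of 1-phenyl-1H-tetrazol-5-yl for 1-methyl-1H-tetrazol-5-yl gives an at least 2.0-fold lower number from compound 3 to compound 4 (0.31 log units; beyond the scatter), the first reading for a change on this tetrazole nitrogen, and it shows that the number can move beyond the scatter at this position. With the methyl on the tetrazole held in place, methyl in place of fluoro on the aromatic carbon gives a 2.2-fold higher number from compound 2 to compound 4 (0.33 log units; beyond the scatter), whereas the earlier change at that carbon, made with phenyl on the tetrazole, could be read only as a floor within the scatter. The true size of the step at the tetrazole nitrogen remains unknown because compound 3 stays at a limit of the assay: the limit of > 500 ug/mL in this assay, at which 1 of the 4 values shown sits.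

The compounds shown leave open how the number responds to other groups on this tetrazole nitrogen, such as a longer chain like propyl, or a chain ending in an amine or a carboxylic acid. They also leave open whether the exchange of phenyl for methyl has a similar size with bromo on the aromatic carbon, where the starting value of compound 1 is a number rather than a limit.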